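The source may hold more compounds than are shown below. What is called first, only, known or untested is meant among the compounds shown, and "the series" means these compounds.

Two members of this pair of chalcone-like pyrazoles have been tested in a functional assay on OVCAR-3 cells (Homo sapiens) for inhibition, read by sulforhodamine B assay, with a stated time of 48 h; on this read-out higher numbers stand for weaker inhibition of growth and lower numbers for stronger inhibition of growth. Compound 1 `COc1cc(-c2cc(/C=C/C(=O)c3ccc(Cl)c(Cl)c3)[nH]n2)cc(OC)c1OC` gives 37800 nM in this assay. Compound 2 `COc1ccc(C(=O)/C=C/c2cc(-c3cc(OC)c(OC)c(OC)c3)n[nH]2)cc1` gives 3560 nM in this assay, the lower of the two numbers shown, its nearest neighbour being compound 1, reached by an 11-fold lower number from compound 1 to compound 2 (1.03 log units; beyond the scatter).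

Compound 3 `COc1ccc(C(=O)/C=C/c2cc(-c3cc(OC)c(OC)c(OC)c3)n[nH]2)cc1OC` is the untested member. It differs from compound 2 by methoxy in place of hydrogen on an aromatic carbon. Within the data shown here, no measured step covers this change; the only step available, the exchange of 3,4-dichlorophenyl for 4-methoxyphenyl on the carbonyl carbon from compound 1 to compound 2, concerns a different part of the same ring and is of no direct help. Among the measured compounds shown here, with no precedent for a further methoxy group on that ring, the expectation for compound 3 in this assay is a step of a 1.0-fold lower number from compound 2 to compound 3 (0.01 log units; within the scatter), not beyond the scatter. Compound 3 is therefore estimated at 3500 nM, with a range of 1500 nM to 9000 nM.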

Compound 3, concentration for total growth inhibition: 3170 nM
Compound 3: middle estimate off by 1.1-fold (0.04 log units), on the high side, within the range that was stated.
By their numbers in this assay, from the lowest: compounds 3 and 2 (each within the scatter of the next); then compound 1.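

In this assay, the position ortho to a methoxy group on the aryl ketone ring accepts methoxy in place of hydrogen with no change beyond the scatter (a 1.1-fold lower number from compound 2 to compound 3 (0.05 log units; within the scatter)), so 4-methoxyphenyl and 3,4-dimethoxyphenyl cannot be told apart here. The replacement of 3,4-dichlorophenyl by 3,4-dimethoxyphenyl is a large step (a 12-fold lower number from compound 1 to compound 3 (1.08 log units; beyond the scatter)), and in this small set both methoxy-bearing rings give lower numbers than the dichlorinated ring of compound 1. No supporting data bear on why the extra methoxy leaves the number within the scatter.

As far as these compounds go, it remains open whether this position would also accept a hydroxy group, an amine or a longer chain such as butoxy. These three compounds also do not show whether 3-methoxyphenyl alone would match 3,4-dimethoxyphenyl.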